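Cyclopropyl in place of dichlorophenyl on the amine-linked chain

The source may hold more compounds than are shown below. What is called first, only, known or untested is meant among the compounds shown, and "the series" means these compounds.

Measured so far in a functional assay on HEK293 cells for agonist activity at G-protein coupled receptor 39 (Homo sapiens), read by inositol phosphate accumulation; a lower number here means that less compound is needed, a higher number that more compound is needed for the effect:
compound 1 `CNc1nc(NCc2ccc(Cl)cc2Cl)cc(-c2ccccn2)n1` gives 0.8 nM;
compound 2 `CNc1nc(NC2(c3ccc(Cl)cc3)CCC2)cc(-c2ccccn2)n1` gives 25 nM.

Compound 1 holds the lowest number of the two, and compound 2 sits well above it, a gap beyond the scatter. Compound 3 `CNc1nc(NCC2CC2)cc(-c2ccccn2)n1` is not yet measured; it differs from compound 1 by cyclopropyl in place of 2,4-dichlorophenyl on a saturated chain carbon bound to a nitrogen on an aromatic ring. Among the measured compounds shown here, no measured pair follows this change, so its size is a guess. In this assay the expected step is a 250-fold higher number from compound 1 to compound 3 (2.40 log units; beyond the scatter), upward and beyond the scatter. Compound 3 is estimated at 200 nM, with a range from 30 nM to 2000 nM.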

Compound 3, half-maximal effective concentration: 164 nM
Compound 3: middle estimate off by 1.2-fold (0.09 log units), on the high side; the range from low to high includes it.
By their numbers in this assay, from the lowest: compound 1; then compound 2; then compound 3.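

In this assay, cyclopropyl in place of 2,4-dichlorophenyl on the saturated chain carbon bound to the aromatic nitrogen brings a 210-fold higher number from compound 1 to compound 3 (2.31 log units; beyond the scatter). This single change to the shared core shows that the number depends strongly on the group at this place, and that cyclopropyl does not stand in for 2,4-dichlorophenyl there. Nothing measured explains the size of this step. Still open, on these data alone, is whether the chlorines or the aromatic ring itself matter more. An unsubstituted phenyl at this place would separate the two.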